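A few compounds are considered here, and "the series" means these few. Any claim that something is new, unique, unknown or untested is made for them only; others in the source may bear on it.

In a functional assay on the whole organism (strain Sprague-Dawley) for inhibition, with Rattus norvegicus as the target, with a stated time of 10 min (on this read-out lower numbers stand for an effect already at smaller amounts and higher numbers for an effect only at larger amounts of compound), compound 1 `COc1ccccc1-c1ncc(C(=O)O)c(=O)[nH]1` gives 10 mg/kg. Compound 2 `COc1ccc(-c2ncc(C(=O)O)c(=O)[nH]2)cc1` gives > 5 mg/kg, which is a limit of the assay and not a number. Compound 3 `COc1ccc(-c2ncc(C(=O)O)c(=O)[nH]2)c(OC)c1` differs from compound 2 by methoxy in place of hydrogen on an aromatic carbon, ortho to a large group. Compound 1, at 10 mg/kg, also carries a methoxy ortho to a large group, so a measurable dose is expected for compound 3. The expected step that the limit leaves unreadable from compound 2 to compound 3 stays within the usual scatter. For compound 3 the estimated dose is 6 mg/kg, with an expected range of 2 mg/kg to 20 mg/kg.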

Compound 3, dose for 50% inhibition: 5 mg/kg
For compound 3 the middle estimate is 1.2-fold (0.08 log units) above the measured one, within the range that was stated.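

In this assay, a methoxy ortho to a large group now appears with a second methoxy on the same ring, and this gives a 2.0-fold lower number from compound 1 to compound 3 (0.30 log units; within the scatter), so the two doses cannot be told apart. The step that adds this methoxy gives a number no higher from compound 2 to compound 3 (the limit leaves the size open), and its size cannot be read because one end of it is a limit and not a number: the limit of > 5 mg/kg in this assay, at which 1 of the 3 values shown sits.

As far as these compounds go, whether this methoxy changes the dose at all therefore remains open. So does the outcome of a different group at this place, such as an amine or a longer chain like butoxy.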